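Sulfur for oxygen in the side chain of compound 3

This account rests on a few compounds, and the source may have more. Where it says the series, first, only, none or still open, it means among the compounds named here.

Of the compounds shown here, three have been measured in an assay on HEK293 cells for displacement of a labelled ligand from 5-hydroxytryptamine receptor 6 (Homo sapiens), read by radioligand binding, with a stated time of 1 h; on this read-out higher numbers stand for weaker inhibition and lower numbers for stronger inhibition. Compound 1 `CN1CCN(c2nc(N)nc(COc3ccccc3Cl)n2)CC1` gives 129 nM. Compound 2 `Cc1cc(OCc2nc(N)nc(N3CCN(C)CC3)n2)ccc1Cl` gives 355 nM; exchanging the ring on the oxygen yields a 2.8-fold higher number from compound 1 to compound 2 (0.44 log units; beyond the scatter). Compound 3 `CC(Oc1ccccc1Cl)c1nc(N)nc(N2CCN(C)CC2)n1` gives 23 nM; the added methyl yields a 5.6-fold lower number from compound 1 to compound 3 (0.75 log units; beyond the scatter). Compound 3 thus stands lowest of the three numbers, with compound 1 nearest and compound 2 furthest.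

Compound 4 `CC(Sc1ccccc1Cl)c1nc(N)nc(N2CCN(C)CC2)n1` awaits measurement in this assay. It differs from compound 3 by (2-chlorophenyl)sulfanyl in place of 2-chlorophenoxy on a saturated chain carbon bound to an aromatic carbon and a saturated chain carbon. Neither measured step bears directly on this change: one varied the ring on the oxygen, the other the methyl on the saturated carbon, and both were modest in size. Within the data shown here, no measured pair exchanges the oxygen itself, so the direction is open; a step of comparable or smaller size than those seen is expected, leaning toward a somewhat higher number. Compound 4 is expected to give about 35 nM in this assay, within a range of 12 nM to 110 nM. This estimate corresponds to an expected step of a 1.5-fold higher number from compound 3 to compound 4 (0.18 log units; within the scatter).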

Compound 4, inhibition constant: 19 nM
Compound 4: the middle estimate sits 1.8-fold (0.27 log units) above what was measured, within the range that was stated.
By their numbers in this assay, from the lowest: compounds 4 and 3 (each within the scatter of the next); then compound 1; then compound 2.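

With (2-chlorophenyl)sulfanyl in place of 2-chlorophenoxy, this assay gives a 1.2-fold lower number from compound 3 to compound 4 (0.08 log units; within the scatter), so oxygen and sulfur are interchangeable at this place on the evidence of this pair. Among these compounds, the earlier steps, a 2.8-fold higher number from compound 1 to compound 2 (0.44 log units; beyond the scatter) and a 5.6-fold lower number from compound 1 to compound 3 (0.75 log units; beyond the scatter), varied the ring and the methyl and both lay beyond the scatter, whereas this pair is the first to vary the atom that links the ring to the saturated chain carbon, and its step stays within the scatter. Nothing available explains this outcome.

From the compounds shown here alone, whether an amine or a sulfone at the same place would also give a number in this range remains open. So does whether the methyl on the saturated chain carbon counts for as much with sulfur as with oxygen.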